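This account rests on a few compounds, and the source may have more. Where it says the series, first, only, none or still open, it means among the compounds named here.

Of the compounds shown here, three have so far been measured in an ADME assay on RAW264.7 cells (Mus musculus) for cytotoxicity, read by MTT assay, with a stated time of 48 h; on this read-out lower numbers stand for higher toxicity in this test and higher numbers for lower toxicity in this test. Compound 1 `C#CCOc1ccc(-c2noc(NC3CCCCC3)n2)cc1` gives 38.3 ug/mL in this assay. Compound 2 `CC(=O)OC[C@H]1O[C@H](OC[C@@H](Cn2cc(CN(c3nc(-c4ccc(C)cc4)no3)C3CCCCC3)nn2)OC(C)=O)C=C[C@@H]1OC(C)=O` gives 45.3 ug/mL in this assay, which is the highest of the three numbers, although its gaps to the other two both lie within the usual scatter of the test. Compound 3 `CCCCCCCCCCc1cn(C[C@@H](CO[C@@H]2C=C[C@H](OC(C)=O)[C@@H](COC(C)=O)O2)OC(C)=O)nn1` gives 30.4 ug/mL in this assay. Compound 1 sits nearest to compound 2 and compound 3 furthest from it, yet neither gap is large enough to say that these compounds truly differ in this assay.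

Compound 4 `COc1ccc(-c2noc(N(Cc3cn(C[C@H](CO[C@@H]4C=C[C@H](OC(C)=O)[C@@H](COC(C)=O)O4)OC(C)=O)nn3)C3CCCCC3)n2)cc1` has not yet been measured in this assay. It is built from compound 2 by one change: methoxy in place of methyl on an aromatic carbon. The same difference, cut one bond further out, reads 4-methylphenyl to 4-methoxyphenyl.

Within the data shown here, no step between two measured compounds shows how such an exchange acts in this assay, so nothing among the measured compounds points to a direction. The change is small in what is counted, and the three measured compounds, though varied in structure, all fall within the scatter of one another. Compound 4 is therefore expected to stay close to compound 2, with the step of a 1.1-fold lower number from compound 2 to compound 4 (0.03 log units; within the scatter) estimated to lie within the scatter, in no particular direction. For compound 4 the estimate in this assay is 42 ug/mL, with a range from 24 ug/mL to 72 ug/mL.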

Compound 4, half-maximal cytotoxic concentration: 86.3 ug/mL
The estimate for compound 4 lay 2.1-fold (0.31 log units) below the measured number, and the stated range ends below it.
By their numbers in this assay, from the lowest: compounds 3, 1, 2 and 4 (each within the scatter of the next, the first and the last beyond it).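

Among these compounds, this is the first step between two measured compounds that differ in one place, and it gives a direct reading for this position on the six-membered aromatic ring. In this assay, methoxy in place of methyl on an aromatic carbon, para to a large group, gives a 1.9-fold higher number from compound 2 to compound 4 (0.28 log units; within the scatter) and so does not separate the two compounds. The exchange adds one oxygen and one hydrogen-bond acceptor at this position, with no step beyond the scatter, but no measurement given here bears on what lies behind the numbers for this pair.

The compounds shown leave open whether another group at this place, such as an amine, a carboxylic acid, chlorine or a longer chain like butoxy, would give a step beyond the scatter. Among the compounds shown here, they also leave open whether the exchange from methyl to methoxy would read the same way with a different group in place of the cyclohexyl on the nitrogen, since this single pair is the only step available.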